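Series notes: naphthalen-2-yl for phenyl, compound 3 pending

This account rests on a few compounds, and the source may have more. Where it says the series, first, only, none or still open, it means among the compounds named here.

In a functional assay on RPMI 8402 cells (Homo sapiens) for cytotoxicity (a lower number here means a stronger inhibitor, a higher number a weaker inhibitor), compound 2 `c1ccc(-c2ccc3[nH]c(-c4ccc5[nH]c(-c6ccc7[nH]cnc7c6)nc5c4)nc3c2)cc1` gives 90 nM. Its only comparison is compound 1 `CCc1nc2cc(-c3nc4cc(-c5nc6cc(-c7ccccc7)ccc6[nH]5)ccc4[nH]3)ccc2[nH]1`, which in this assay gives 110 nM; the step of a 1.2-fold lower number from compound 1 to compound 2 (0.09 log units; within the scatter) is within the scatter, so the two compounds stand together rather than apart, and compound 2 is not set off from compound 1 by the numbers shown.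

Compound 3 `c1ccc2cc(-c3ccc4[nH]c(-c5ccc6[nH]c(-c7ccc8[nH]cnc8c7)nc6c5)nc4c3)ccc2c1` is not yet measured. It differs from compound 2 by naphthalen-2-yl in place of phenyl on an aromatic carbon. Going by the values given here, no measured step concerns the group at this position; the one step known, a 1.2-fold lower number from compound 1 to compound 2 (0.09 log units; within the scatter), is at another place and within the scatter, so it gives no direction for the present change. With nothing in the series pointing either way, a step of no change at the digits printed from compound 2 to compound 3 (within the scatter) is expected, not beyond the scatter. Compound 3 is estimated at 90 nM, with a range of 30 nM to 270 nM.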

Compound 3, half-maximal inhibitory concentration: 80 nM
Compound 3: the middle estimate sits 1.1-fold (0.05 log units) above what was measured; the measured number falls inside the stated range.
By their numbers in this assay, from the lowest: compounds 3, 2 and 1 (each within the scatter of the next).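

In this assay the aromatic carbon that carries phenyl in compound 2 now has its first measured change, and naphthalen-2-yl in place of phenyl gives a 1.1-fold lower number from compound 2 to compound 3 (0.05 log units; within the scatter). The position therefore takes a second six-membered aromatic ring of carbon only, going from 6 to 10 heavy atoms, with compound 2 and compound 3 standing together in this read-out; with the earlier step from compound 1 to compound 2, neither of the two changes at separate places sets a compound apart. Nothing measured on these compounds offers an explanation for this flat result.

Still open, as far as these compounds go, is whether a group bearing an amine or a carboxylic acid at this position would shift the number beyond the scatter. From the compounds shown here alone, the effect of a small group such as methyl, or of the isomeric naphthalen-1-yl, also remains open.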